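The compounds below may be only part of what the source reports. "The series", "measured", "known", "first", "only" and "open" are said of these compounds alone.

The measured compounds:

Compound 1, `CC(Nc1ccccc1Oc1ccc(Cl)cc1)=C1C(=O)CC(c2ccccc2)CC1=O`, gives 260 nM in a functional assay on HMEC-1 cells (Homo sapiens) for antiproliferative activity, read by cell counting, with a stated time of 4 days; a lower number here means a stronger inhibitor, a higher number a weaker inhibitor.
Compound 2, `CC(Nc1ccccc1Oc1ccccc1)=C1C(=O)CC(c2ccccc2)CC1=O`, gives 160 nM in this assay.
Compound 3, `CCOc1ccccc1NC(C)=C1C(=O)CC(c2ccccc2)CC1=O`, gives 100 nM in this assay.

Among these three, compound 1 carries the highest number. Its gap to compound 2 is a 1.6-fold lower number from compound 1 to compound 2 (0.21 log units; within the scatter), and its gap to compound 3 is a 2.6-fold lower number from compound 1 to compound 3 (0.41 log units; beyond the scatter); between compound 2 and compound 3 the step is a 1.6-fold lower number from compound 2 to compound 3 (0.20 log units; within the scatter).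

The unmeasured compound 4, `COc1ccc(Oc2ccccc2NC(C)=C2C(=O)CC(c3ccccc3)CC2=O)cc1OC`, differs from compound 1 in one place: 3,4-dimethoxyphenyl in place of 4-chlorophenyl on an oxygen on an aromatic ring. Going by the values given here, two measured steps bear on it. Removing the chloro, as in going from compound 1 to compound 2, gave a 1.6-fold lower number from compound 1 to compound 2 (0.21 log units; within the scatter); exchanging the whole aryl group for ethyl, as from compound 2 to compound 3, gave a 1.6-fold lower number from compound 2 to compound 3 (0.20 log units; within the scatter). Neither step passed the scatter, so the shared core appears to tolerate changes at this oxygen without a large shift. For compound 4 a small move toward a lower number, a 1.4-fold lower number from compound 1 to compound 4 (0.16 log units; within the scatter), is therefore expected, and the value of compound 4 in this assay is estimated at 180 nM, within 80 nM to 400 nM.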

Compound 4, half-maximal inhibitory concentration: 140 nM
The estimate for compound 4 lay 1.3-fold (0.11 log units) above the measured number; the measured number falls inside the stated range.
By their numbers in this assay, from the lowest: compounds 3, 4, 2 and 1 (each within the scatter of the next, the first and the last beyond it).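

In this assay, 3,4-dimethoxyphenyl, with more heavy atoms than 4-chlorophenyl, was accepted on this oxygen with every new step inside the scatter: a 1.9-fold lower number from compound 1 to compound 4 (0.27 log units; within the scatter), a 1.1-fold lower number from compound 2 to compound 4 (0.06 log units; within the scatter) and a 1.4-fold higher number from compound 3 to compound 4 (0.15 log units; within the scatter). The earlier compounds had shown this tolerance only for removing the chloro and for the exchange of phenyl for ethyl, whereas compound 4 extends it to an aryl group with hydrogen-bond acceptors, which 4-chlorophenyl does not have. No supporting evidence bears on this result.

The groups shown on this oxygen are aryl groups and ethyl, so it remains open whether a carboxylic acid or a longer chain ending in an amine would shift the number beyond the scatter. Also open, on these data alone, is how a phenyl group carrying a single methoxy would compare with compound 4.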